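The compounds below may be only part of what the source reports. "The series", "measured", "known", "first", "only" and "open" are said of these compounds alone.

Measured so far in a functional assay on NCI-H520 cells (Homo sapiens) for inhibition, read by MTT assay, with a stated time of 48 h, tested at 10 uM; a lower number here means less inhibition, a higher number more inhibition at the concentration tested (going by the name of the read-out):

compound 1, `Cc1ccc(Nc2cc(NC(=O)Nc3c(Cl)cccc3Cl)ncn2)cc1C`, 47.5%
compound 2, `COc1cc(NC(=O)Nc2cc(Nc3cc(C(F)(F)F)ccc3OC)ncn2)cc(OC)c1`, 63%
compound 3, `COc1ccc(C(F)(F)F)cc1Nc1cc(NC(=O)Nc2c(Cl)cccc2Cl)ncn1`, 33%

Compound 1 stands second highest of the three numbers in this assay . Its nearest neighbour is compound 3, whose value is lower by a margin beyond the scatter; compound 2 lies higher, also beyond the scatter. Among the measured compounds shown here, the only step between two measured compounds that differ in one place is a number 30 percentage points lower from compound 2 to compound 3 (beyond the scatter), and it concerns the aryl group on the amide-type nitrogen, not the nitrogen on the aromatic ring of the shared core.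

Compound 4, `O=C(Nc1cc(Nc2ccc(F)c(Cl)c2)ncn1)Nc1c(Cl)cccc1Cl`, has not yet been measured in this assay . Against compound 1 it differs by 3-chloro-4-fluorophenyl in place of 3,4-dimethylphenyl on a nitrogen on an aromatic ring. For the measured compounds named here, no measured step bears directly on this position. Compound 1 and compound 3 share the 2,6-dichlorophenyl group on the amide-type nitrogen and differ only in the aryl group on the ring nitrogen; their two values show that this position can move the read-out by a modest margin, with compound 1 the higher of the two. The change to compound 4 is therefore expected to produce at most a small step, in no firmly predictable direction.

Compound 4 is expected to give about 45% in this assay , within 25% to 65%, which would mean a step of a number 2.5 percentage points lower from compound 1 to compound 4 (within the scatter).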

Compound 4, a percentage reported as inhibition, at one concentration (the size of the read-out at that concentration, not a potency): 39.5%
Compound 4: the middle estimate sits 5.5 percentage points above what was measured; the measured number falls inside the stated range.
By their numbers in this assay, from the lowest: compounds 3, 4 and 1 (each within the scatter of the next, the first and the last beyond it); then compound 2.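

In this assay, among the compounds shown here, the change to 3-chloro-4-fluorophenyl in place of 3,4-dimethylphenyl on a nitrogen on an aromatic ring gives a number 8 percentage points lower from compound 1 to compound 4 (within the scatter), the only directly read step at this position, with the 2,6-dichlorophenyl group on the amide-type nitrogen held constant; replacing the carbon-only substituents of the ring with a fluorine and a chlorine therefore produces no separable change in this read-out. The position is also now seen as less clear-cut than the two earlier values suggested: compound 4, at 39.5%, lies within the scatter of both compound 1, at 47.5%, and compound 3, at 33%, although those last two lie beyond the scatter of each other. No measurement on hand explains the values at this position.

Open, as far as these compounds go, is whether the 3-chloro-4-fluorophenyl group would give a similar result when paired with the 3,5-dimethoxyphenyl group on the amide-type nitrogen of compound 2. Also open, from the compounds shown here alone, is how this position would respond to a morpholine in place of the aryl amine, or to a carboxylic acid on the aryl ring.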